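The source may hold more compounds than are shown below. What is called first, only, known or untested is meant among the compounds shown, and "the series" means these compounds.

Within the data shown here, in an in vitro assay on BTI-TN-5B1-4 cells for inhibition of Amine oxidase [flavin-containing] B (Homo sapiens) (a higher number here means a weaker inhibitor, a lower number a stronger inhibitor), compound 3 `COc1ccc(C2CC(=O)c3ccc(OC)cc3O2)cc1` gives 7180 nM, the highest of the three numbers so far; compound 2 `Cc1ccc(C2CC(=O)c3ccc(C)cc3O2)cc1` gives 500 nM and compound 1 `Cc1ccc(C2CC(=O)c3ccc(F)cc3O2)cc1` gives 160 nM. Compound 4 `COc1ccc2c(c1)OC(c1ccc(C)cc1)CC2=O` has not yet been measured; it differs from compound 3 by methyl in place of methoxy on an aromatic carbon. Among the measured compounds shown here, no measured step swaps methoxy for methyl directly. For the measured compounds named here, the only single-change step on record, a 3.1-fold higher number from compound 1 to compound 2 (0.49 log units; beyond the scatter), concerns the fused ring and a different pair of groups, so it indicates the scale of a one-group swap rather than its direction. Compound 2, which carries methyl on both rings, and compound 3, which carries methoxy on both, differ by two such swaps, and compound 4 sits halfway between them in structure. Compound 4 is therefore expected to come in well under compound 3 in this assay. The expected step, toward a lower number, is a 3.6-fold lower number from compound 3 to compound 4 (0.56 log units; beyond the scatter). The estimate for compound 4 is 2000 nM, with a range from 700 nM to 6000 nM.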

Compound 4, half-maximal inhibitory concentration: 550 nM
Compound 4: middle estimate off by 3.6-fold (0.56 log units), on the high side; the measured number lies below the stated range.
By their numbers in this assay, from the lowest: compound 1; then compounds 2 and 4 (each within the scatter of the next); then compound 3.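

In this assay, among these compounds, the single exchange at this aromatic carbon, para to a large group, gives a large step, a 13-fold lower number from compound 3 to compound 4 (1.12 log units; beyond the scatter) and so shows that the high number of compound 3 is tied to the methoxy at this site. The reverse exchange on the other aromatic ring gives only a 1.1-fold higher number from compound 2 to compound 4 (0.04 log units; within the scatter) so methoxy and methyl cannot be told apart there, and the outcome of this swap depends on which ring carries it. On that same ring, fluoro and methoxy do separate, with a 3.4-fold higher number from compound 1 to compound 4 (0.54 log units; beyond the scatter) as a modest step.

Still open, on these data alone, is how a chloro, hydroxyl or amine group would read at the carbon para to a large group, and whether fluoro there would match its modest advantage on the other ring. Nothing at hand explains why the two rings respond so differently to this exchange.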